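Fluoro step on the compound 2 core

The source may hold more compounds than are shown below. What is called first, only, known or untested is meant among the compounds shown, and "the series" means these compounds.

Measured in a functional assay on HeLa cells (Homo sapiens) for antiproliferative activity, with a stated time of 48 h; a lower number here means a stronger inhibitor, a higher number a weaker inhibitor:
- compound 1 `C=C(Br)C(=O)Nc1ccc(/C=C/C(=O)c2ccc(F)cc2)cc1`: 1400 nM
- compound 2 `Nc1ccc(/C=C/C(=O)c2ccccc2)cc1`: 36000 nM

Compound 2 holds the higher of the two numbers, and the gap down to compound 1 lies beyond the scatter. Compound 3 `Nc1ccc(/C=C/C(=O)c2ccc(F)cc2)cc1` is compound 2 with fluoro in place of hydrogen on an aromatic carbon, para to a large group (fluoro in place of hydrogen on an aromatic carbon). Going by the values given here, no measured pair shows this change alone. Only a small step is expected in this assay, leaning toward a lower number and probably within the scatter. The expected step is a 1.6-fold lower number from compound 2 to compound 3 (0.21 log units; within the scatter). The estimate for compound 3 is 22000 nM, with an expected range of 8000 nM to 55000 nM.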

Compound 3, half-maximal inhibitory concentration: 40000 nM
The estimate for compound 3 lay 1.8-fold (0.26 log units) below the measured number, within the range that was stated.
By their numbers in this assay, from the lowest: compound 1; then compounds 2 and 3 (each within the scatter of the next).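

In this assay, fluoro in place of hydrogen on an aromatic carbon, para to a large group, gives a 1.1-fold higher number from compound 2 to compound 3 (0.05 log units; within the scatter), so on the free amine this change does not separate the two compounds. Hydrogen in place of (1-bromoethenyl)carbonyl on the nitrogen gives a 29-fold higher number from compound 1 to compound 3 (1.46 log units; beyond the scatter), which places the large step at that nitrogen rather than at the fluoro. No evidence on the cause of either step is available. Going by these compounds, it remains open whether a chloroacetyl or a plain acetyl on that nitrogen would match the (1-bromoethenyl)carbonyl. Also open, on these data alone, is whether a methoxy or a chlorine on that aromatic carbon would read like fluoro.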